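Swapping the Furan for Phenyl on the Amide Carbonyl

The source may hold more compounds than are shown below. What is called first, only, known or untested is meant among the compounds shown, and "the series" means these compounds.

Of the compounds shown here, three sharing one core have been measured in a functional assay on MKN-45 cells (Homo sapiens) for cytotoxicity; on this read-out higher numbers stand for weaker inhibition and lower numbers for stronger inhibition. Compound 1 `COc1ccc(S(=O)(=O)N2CCc3cc(Br)cc(NC(=O)c4ccco4)c32)cc1` gives 78 nM, and compound 2 `COc1ccc(S(=O)(=O)N2CCc3cc(Br)cc(NC(=O)c4ccncc4)c32)cc1` gives 86 nM. Compound 3 `COc1ccc(S(=O)(=O)N2CCc3cccc(NC(=O)c4ccco4)c32)cc1` gives 10.7 nM, the lowest of the three numbers; its nearest neighbour is compound 1, which sits higher by a step beyond the scatter, and compound 2 lies a little further still.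

Two steps connect these values. The step of a 1.1-fold higher number from compound 1 to compound 2 (0.04 log units; within the scatter) shows that exchanging one aryl group for another on the carbonyl carbon left the number essentially unchanged. The step of a 7.3-fold lower number from compound 1 to compound 3 (0.86 log units; beyond the scatter) shows the modest gain that came with removing the bromo group.

Compound 4 `COc1ccc(S(=O)(=O)N2CCc3cccc(NC(=O)c4ccccc4)c32)cc1` is obtained from compound 3 by the change (phenyl in place of furan-2-yl on a carbonyl carbon). The relevant precedent is the aryl swap from compound 1 to compound 2, which stayed within the scatter, so a similar swap on the same carbonyl carbon is expected to leave the number near where compound 3 stands, with no step beyond the scatter in either direction. Compound 4 is therefore estimated at 12 nM, with a range from 5 nM to 30 nM, and the expected step is a 1.1-fold higher number from compound 3 to compound 4 (0.05 log units; within the scatter).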

Compound 4, half-maximal inhibitory concentration: 250 nM
Estimate against measurement, compound 4: 21-fold (1.32 log units) below; measured number outside the range, above it.
By their numbers in this assay, from the lowest: compound 3; then compounds 1 and 2 (each within the scatter of the next); then compound 4.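

In this assay, the step of a 23-fold higher number from compound 3 to compound 4 (1.37 log units; beyond the scatter) shows that the aryl group on this carbonyl carbon is not freely exchangeable: phenyl in place of furan-2-yl carries a large penalty on the core without bromo. The earlier swap, a 1.1-fold higher number from compound 1 to compound 2 (0.04 log units; within the scatter), put pyridin-4-yl in place of furan-2-yl on the bromo-bearing core and stayed within the scatter, so that flat result does not hold for every aryl exchange at this position. Nothing shown here gives a measured account of why the phenyl exchange has so large an effect on this read-out.

The two aryl swaps differ in both the entering group and the presence of the bromo group, so the compounds shown cannot tell whether the contrast comes from phenyl as against pyridin-4-yl or from the bromo group, and a phenyl amide carrying bromo or a pyridin-4-yl amide without it would separate the two. Also open, going by these compounds, is how this position responds to other groups on the carbonyl carbon, such as thiophen-2-yl, with sulfur in the ring in place of the furan oxygen, or a saturated cyclohexyl ring.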